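Compound 4 and a hydroxy lost at the limit

The compounds below may be only part of what the source reports. "The series", "measured", "known", "first", "only" and "open" are said of these compounds alone.

In a functional assay on HL-60 cells (Homo sapiens) for cytotoxicity (a lower number here means a stronger inhibitor, a higher number a weaker inhibitor), compound 2 (`COc1c(C)c(/C=C/C(=O)O)oc(=O)c1CO`) gives > 50000 nM as a limit and not a number. Compound 1 (`COC(=O)C1C(c2oc(=O)c(CO)c(OC)c2CO)C(C(=O)OC)C1c1oc(=O)c(CO)c(OC)c1CO`) also gives a limit, > 50000 nM in this assay as well. Compound 3 (`COc1c(CO)c(/C=C/C(=O)O)oc(=O)c1CO`) likewise gives only a limit, > 50000 nM again. Compound 4 (`COc1c(C)c(/C=C/C(=O)O)oc(=O)c1C`) differs from compound 2 by hydrogen in place of hydroxy on a saturated chain carbon bound to an aromatic carbon with hydrogen in place of hydroxy, which is hydroxymethyl to methyl. Going by the values given here, the one measured step of this kind is a step that the two limits leave unreadable from compound 2 to compound 3 and it has no readable size. No size can be carried over because the limit of > 50000 nM in this assay, at which 3 of the 3 values shown sit, is all that these compounds show. The expected change is a number no higher from compound 2 to compound 4 (the limit leaves the size open) with no direction expected beyond the scatter. Compound 4 is estimated at 50000 nM (15000 nM to 100000 nM) and most likely stays a limit.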

Compound 4, half-maximal inhibitory concentration: > 50000 nM
Compound 4: a limit, no number (the forecaster's own chance of this, stated with the estimate: 75%); the middle value lies on the limit itself.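

The step between compound 2 and compound 4 cannot be read, as both values are limits and not numbers. The compounds shown leave open whether hydroxymethyl to methyl changes the cytotoxicity at all, with one thing to read: the limit of > 50000 nM in this assay, at which 4 of the 4 values shown sit.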